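Enantiomer of compound 3 at the Substance-P receptor

The source may report more compounds than this note shows. Statements on the series, on what has been measured and on what is new or still open speak of the compounds shown alone.

Measured so far:
compound 1 `O=C1NC(COCc2cc(C(F)(F)F)cc(C(F)(F)F)c2)(c2ccc(F)cc2)CN1C1CCNCC1` — 0.9 nM
compound 2 `O=C1NC[C@@](COCc2cc(C(F)(F)F)cc(C(F)(F)F)c2)(c2ccccc2)N1` — 6 nM
compound 3 `O=C1NC[C@@](COCc2cc(C(F)(F)F)cc(C(F)(F)F)c2)(c2ccc(F)cc2)N1` — 2.7 nM

In an assay on CHO cells for displacement of a labelled ligand from Substance-P receptor (Homo sapiens) (a lower number here means a stronger inhibitor, a higher number a weaker inhibitor), compound 3 gives 2.7 nM, the second highest of the three numbers. Its nearest neighbour is compound 2 with 6 nM, a higher number beyond the scatter, and the furthest is compound 1 with 0.9 nM, a lower number beyond the scatter and the lowest of the set. Among the measured compounds shown here, the only single-point step among the measured compounds is a 2.2-fold lower number from compound 2 to compound 3 (0.35 log units; beyond the scatter), a fluoro in place of hydrogen on an aromatic carbon.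

Compound 4 `O=C1NC[C@](COCc2cc(C(F)(F)F)cc(C(F)(F)F)c2)(c2ccc(F)cc2)N1` is the next compound. Relative to compound 3, (the two compounds have the same atoms and bonds and differ only in configuration as drawn: 1 of 1 stereo elements differ; a stereocentre at a saturated ring carbon is drawn R in compound 3 and S in compound 4). For the measured compounds named here, no measured step bears on a change of configuration: the one recorded step concerns a substituent, not the stereocentre, so it gives no size or direction to borrow. The expectation for compound 4 therefore rests on the bare fact that the two compounds share every atom and bond and differ only at the saturated ring carbon, which leaves the outcome open in both directions and calls for a wide range. A higher number is tentatively expected for compound 4, as an 11-fold higher number from compound 3 to compound 4 (1.05 log units; beyond the scatter). The estimate for compound 4 in this assay is 30 nM, between 3 nM and 300 nM.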

Compound 4, inhibition constant: 89 nM
The estimate for compound 4 lay 3.0-fold (0.47 log units) below the measured number, and the stated range covers the measured number.
By their numbers in this assay, from the lowest: compound 1; then compound 3; then compound 2; then compound 4.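

In this assay, the configuration at the saturated ring carbon carries a large effect: going from R to S gives a 33-fold higher number from compound 3 to compound 4 (1.52 log units; beyond the scatter). Among the compounds shown here, the only earlier step, a 2.2-fold lower number from compound 2 to compound 3 (0.35 log units; beyond the scatter), came from a fluoro in place of hydrogen on an aromatic carbon and was modest, and no earlier step touched the stereocentre, so the weight of this position could not be seen before. The whole of the new step belongs to the stereocentre, because nothing else separates the pair: the fact that compounds 3 and 4 differ only in the configuration as drawn

The compounds shown leave open whether the same preference for the R form holds for the pair without the fluoro, or for the core of compound 1, which is drawn with no configuration at that carbon. They also leave open how a chloro or a methoxy group in place of the fluoro would read in either configuration, and so whether the size of the step depends on that substituent at all.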